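The source may report more compounds than this note shows. Statements on the series, on what has been measured and on what is new or still open speak of the compounds shown alone.

In an ADME assay on L929 cells (Mus musculus) for cytotoxicity, read by resazurin assay, with a stated time of 72 h (on this read-out lower numbers stand for stronger inhibition and higher numbers for weaker inhibition), compound 3 (`O=C(/C=C/c1ccc2c(c1)B(O)OC2)c1ccc(F)cc1`) gives > 10 ug/mL as a limit and not a number. Compound 1 (`O=C(/C=C/c1ccc2c(c1)B(O)OC2)c1ccccc1`) gives > 10 ug/mL as a limit too. Compound 2 (`Cc1ccc(C(=O)/C=C/c2ccc3c(c2)B(O)OC3)cc1C`) gives > 10 ug/mL as a limit as well. All three measured compounds therefore sit at the same limit (the limit of > 10 ug/mL in this assay, at which 3 of the 3 values shown sit) and none can be ranked against another.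

Compound 4 (`Cc1ccc(C(=O)/C=C/c2ccc3c(c2)B(O)OC3)cc1`) differs from compound 3 by methyl in place of fluoro on an aromatic carbon. Within the data shown here, only one measured step touches that place (a step that the two limits leave unreadable from compound 1 to compound 3) and it offers no size to carry over. Methyl on the aromatic ring also occurs in compound 2, which shows > 10 ug/mL as a limit and so gives no measured size either.

No step beyond the scatter is expected in this assay and no direction can be assigned. The estimated step is small (a step that the limit leaves unreadable from compound 3 to compound 4) and carries no firm direction. For compound 4 the estimated value is 15 ug/mL with an expected range from 7 ug/mL to 40 ug/mL as the working figure. A reading at the same limit is the most likely outcome expected for compound 4.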

Compound 4, half-maximal inhibitory concentration: > 10 ug/mL
Compound 4 gave a limit, no number (the forecaster's own chance of this, stated with the estimate: 80%); the middle value does not contradict the limit.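

No new step can be read in this assay: the steps from compound 4 to compounds 1, 2 and 3 all join limits and not numbers, and the four compounds sit together: the limit of > 10 ug/mL in this assay, at which 4 of the 4 values shown sit.

The compounds shown leave open whether hydrogen, fluoro and methyl on that aromatic carbon differ at all in this read-out, and where the true value of each compound lies.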